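Swapping a Ring Edge and Watching Cell Tolerance

This account rests on a few compounds, and the source may have more. Where it says the series, first, only, none or still open, it means among the compounds named here.

Of the compounds shown here, two built on a shared core have been measured in an ADME assay on MT2 cells (Homo sapiens) for cytotoxicity, read by XTT assay, with a stated time of 4 days; a higher number here means that more compound is tolerated, a lower number that less compound is tolerated. Compound 1 `Cc1ccc(-c2c(C(OC(C)(C)C)C(=O)O)c(C)nc3cc(-c4ccccc4)nn23)cc1` gives 77000 nM in this assay. Compound 2 `Cc1ccccc1-c1cccc(-c2cc3nc(C)c([C@H](OC(C)(C)C)C(=O)O)c(-c4cc(F)c5c(c4C)CCCO5)n3n2)c1` gives 28200 nM, the lower of the two numbers, so cells tolerated less of it; its distance from compound 1 lies beyond the usual scatter of such measurements.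

Compound 3 `COc1ccc(-c2cccc(-c3cc4nc(C)c([C@H](OC(C)(C)C)C(=O)O)c(-c5cc(F)c6c(c5C)CCCO6)n4n3)c2)cn1` has not yet been measured. It differs from compound 2 in one place:

6-methoxypyridin-3-yl in place of 2-methylphenyl on an aromatic carbon

Among the compounds with values here, no pair of measured compounds differing in a single place is available to show how large such a change tends to be here. The step of a 1.2-fold higher number from compound 2 to compound 3 (0.09 log units; within the scatter) is therefore expected to be modest, if anything a small rise in tolerated concentration, and possibly none beyond the scatter. Compound 3 is estimated at 35000 nM, with a likely range from 15000 nM to 80000 nM.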

Compound 3, half-maximal cytotoxic concentration: > 23000 nM
Compound 3: a limit, no number (the forecaster's own chance of this, stated with the estimate: 15%); the middle value does not contradict the limit.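

Within the data shown here, compound 3 gives a limit of the assay rather than a number, so no step from compound 2 to compound 3 can be read: the limit of > 23000 nM in this assay, at which 1 of the 3 values shown sits. Going by these compounds, whether 6-methoxypyridin-3-yl in place of 2-methylphenyl raises or lowers the number in this assay, and by how much, remains open.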